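This account rests on a few compounds, and the source may have more. Where it says the series, first, only, none or still open, it means among the compounds named here.

Measured compounds:

Compound 1, `O=C(O)/C(O)=C/C(=O)c1cn(Cc2ccc(F)cc2)c2ccc(Br)cc2c1=O`, gives in an ADME assay on TZM cells (Homo sapiens) for cytotoxicity, read by WST assay, with a stated time of 3 days (on this read-out lower numbers stand for higher toxicity in this test and higher numbers for lower toxicity in this test), the value > 1000000 nM, which is a limit of the test and not a number.

Compound 2, `O=C(O)/C(O)=C/C(=O)c1cn(Cc2ccc(F)cc2)c2ccc(OCc3ccc(F)cc3)cc2c1=O`, gives in this assay the value > 1000000 nM, again a limit and not a number.

Both compounds sit at the edge of what the test can report, so the step that the two limits leave unreadable from compound 1 to compound 2 cannot be read as a size in either direction. Compound 2 therefore stands only at the limit of > 1000000 nM in this assay, at which 2 of the 2 values shown sit, with no value of its own to compare against.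

The next compound, compound 3, `O=C(O)/C=C/c1ccc2c(c1)c(=O)c(C(=O)/C=C(\O)C(=O)O)cn2Cc1ccc(F)cc1`, differs from compound 2 in one place: 2-carboxyethenyl in place of (4-fluorobenzyl)oxy on an aromatic carbon. Among the measured compounds shown here, of the measured steps, only the one from compound 1 to compound 2 exists, and its size stays hidden by the two limits, so no measured step gives a scale for this change.

The expectation for compound 3 is that it too reaches the limit of this assay, an estimated step of a number no higher from compound 2 to compound 3 (the limit leaves the size open). Compound 3 is thus estimated at 1000000 nM, within a range from 300000 nM to 3000000 nM.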

Compound 3, half-maximal cytotoxic concentration: > 1000000 nM
Compound 3 was reported as a limit; the forecaster's own chance of this, stated with the estimate: 75%; the middle value lies on the limit itself.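

Compound 3 also ends at a limit of the test in this assay and not at a number, so its steps from compound 1 and from compound 2 cannot be read in size. The compounds shown leave open whether these three differ in toxicity at all, as they all share one reported edge of the test: the limit of > 1000000 nM in this assay, at which 3 of the 3 values shown sit.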